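Trimming a decyl chain to 3-chloropropyl

A few compounds are considered here, and "the series" means these few. Any claim that something is new, unique, unknown or untested is made for them only; others in the source may bear on it.

In a functional assay on HCT-116 cells (Homo sapiens) for antiproliferative activity, read by MTT assay, with a stated time of 72 h (a higher number here means a weaker inhibitor, a lower number a stronger inhibitor), compound 3 `CCCCCCCCCCc1cn(C[C@H](O)[C@H]2OC(=O)C(OCc3ccccc3)=C2OCc2ccccc2)nn1` gives 28800 nM, which lies within the usual scatter of compound 1 `O=C1O[C@H]([C@@H](O)Cn2cc(-c3cccc(O)c3)nn2)C(OCc2ccccc2)=C1OCc1ccccc1` at 42900 nM. Compound 2 `COc1ccccc1-c1cn(C[C@H](O)[C@H]2OC(=O)C(OCc3ccccc3)=C2OCc2ccccc2)nn1` gives only a limit of the assay, > 100000 nM.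

Compound 4 `O=C1O[C@H]([C@@H](O)Cn2cc(CCCCl)nn2)C(OCc2ccccc2)=C1OCc1ccccc1` keeps the shared core and changes the chain: chloro in place of heptyl on a saturated chain carbon, three bonds along the chain from an aromatic carbon. In words, this is chloro in place of heptyl on a saturated chain carbon, three bonds along the chain from an aromatic carbon, which also reads as decyl to 3-chloropropyl.

Among the measured compounds shown here, two measured steps touch the same place. Decyl in place of 3-hydroxyphenyl gave a 1.5-fold lower number from compound 1 to compound 3 (0.17 log units; within the scatter), and decyl in place of 2-methoxyphenyl gave an at least 3.4-fold lower number from compound 2 to compound 3 (0.54 log units; beyond the scatter). Neither step shortens a chain, so they guide only loosely, and the values at this place stay in a narrow band unless the limit is reached.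

The estimated change is a 1.6-fold higher number from compound 3 to compound 4 (0.19 log units; within the scatter), a small rise that stays within the scatter. For compound 4 the expected value is 45000 nM, with an estimated range of 20000 nM to 100000 nM.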

Compound 4, half-maximal inhibitory concentration: 36100 nM
Compound 4: the middle estimate sits 1.2-fold (0.10 log units) above what was measured; the measured number falls inside the stated range.
By their numbers in this assay, from the lowest: compounds 3, 4 and 1 (each within the scatter of the next). At a limit, above all of these: compound 2.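

In this assay, cutting decyl back to 3-chloropropyl changes little (a 1.3-fold higher number from compound 3 to compound 4 (0.10 log units; within the scatter)), so this position accepts a much shorter chain carrying a chlorine without a shift beyond the scatter. The short chain also stays level with the 3-hydroxyphenyl group (a 1.2-fold lower number from compound 1 to compound 4 (0.07 log units; within the scatter)) and keeps the advantage over the 2-methoxyphenyl group (an at least 2.7-fold lower number from compound 2 to compound 4 (0.44 log units; beyond the scatter)), so that advantage does not depend on the long decyl chain. The number for compound 2 is a limit of the assay, not a measured value: the limit of > 100000 nM in this assay, at which 1 of the 4 values shown sits.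

A plain propyl chain would show whether the chlorine matters at all, and an amine in place of the chlorine would test a very different group on the same short chain. On these data alone, whether any group at this position can give a much lower number stays open.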